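Swapping methoxy for methanesulfonamido on compound 3

This account rests on a few compounds, and the source may have more. Where it says the series, first, only, none or still open, it means among the compounds named here.

Going by the values given here, compound 3 `COc1cccc(NC(=O)Nc2cccc(-c3nc(-c4ccc(NC(=O)c5cccnc5)cc4Cl)no3)c2)c1` is the only compound in this set for which a functional assay on MDA-MB-231 cells (Homo sapiens) for antiproliferative activity, read by MTT assay, with a stated time of 72 h (on this read-out lower numbers stand for stronger inhibition and higher numbers for weaker inhibition), returns an actual number: compound 3 gives 6700 nM. Compound 1 `Cc1ccc(S(=O)(=O)Nc2cccc(-c3nc(-c4ccc(NC(=O)c5cccnc5)cc4Cl)no3)c2)cc1` reaches only the limit > 10000 nM in this assay. Compound 2 `COc1cccc(S(=O)(=O)Nc2cccc(-c3nc(-c4ccc(NC(=O)c5cccnc5)cc4Cl)no3)c2)c1` likewise stops at the limit > 10000 nM in this assay. Those two limits, as the limit of > 10000 nM in this assay, at which 2 of the 3 values shown sit, records, leave two steps readable only as floors: an at least 1.4-fold lower number from compound 1 to compound 3 (0.17 log units; that floor lies within the scatter) and an at least 1.4-fold lower number from compound 2 to compound 3 (0.17 log units; that floor lies within the scatter), whereas a step that the two limits leave unreadable from compound 1 to compound 2.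

Compound 4 `CS(=O)(=O)Nc1cccc(NC(=O)Nc2cccc(-c3nc(-c4ccc(NC(=O)c5cccnc5)cc4Cl)no3)c2)c1` has not yet been measured. It differs from compound 3 by methanesulfonamido in place of methoxy on an aromatic carbon. Among the compounds with values here, none of the measured steps touches this spot: the two readable steps replace a whole sulfonyl linker with a carbamoyl linker, and each is only a floor that lies inside the usual scatter, so there is no measured precedent for trading a methoxy for a methanesulfonamido group on that outer ring. The expectation for compound 4 in this assay is therefore a step of a 1.2-fold lower number from compound 3 to compound 4 (0.09 log units; within the scatter), which amounts to no change beyond the scatter. Compound 4 is thus estimated at 5500 nM, with a range from 1500 nM to 20000 nM.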

Compound 4, half-maximal inhibitory concentration: > 10000 nM
Compound 4: no number, only a limit; the forecaster's own chance of this, stated with the estimate: 35%; middle value at least 1.8-fold (0.25 log units) from the limit.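

The change from 3-methoxyphenyl to 3-(methanesulfonamido)phenyl is the first change shown on the outer ring itself rather than on the linker that carries it, and in this assay compound 4 gives only a limit, > 10000 nM. The step therefore reads as an at least 1.4-fold higher number from compound 3 to compound 4 (0.17 log units; that floor lies within the scatter), so the data show no gain from placing methanesulfonamido at this position, but they do not establish a real loss either. Compound 3 remains the only compound with an actual number, and the others now share one ceiling: the limit of > 10000 nM in this assay, at which 3 of the 4 values shown sit.

Going by these compounds, the true value of compound 4 remains unknown beyond its limit, and the step between the two compounds that both stop at a limit, like any comparison of compound 4 with them, cannot be read. Also open, on these data alone, is whether another group at this position, such as an amine, a carboxylic acid or a longer chain like ethoxy, would give a clearly lower number than compound 3 in this assay, or whether this position tolerates any change at all.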